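Extending a Methyl to Ethyl on a Disulfide-Isomerase Inhibitor

This account rests on a few compounds, and the source may have more. Where it says the series, first, only, none or still open, it means among the compounds named here.

Three compounds have been measured in an assay for inhibition of protein disulfide-isomerase (Homo sapiens), with a stated time of 1 h; a lower number here means a stronger inhibitor, a higher number a weaker inhibitor:
compound 1 `Oc1c(C(Nc2ccccn2)c2ccccc2Cl)ccc2cccnc12` gives 500 nM;
compound 2 `Oc1cccc(C(Nc2ccccn2)c2ccc3cccnc3c2O)c1Cl` gives 370 nM;
compound 3 `Cc1ccc(C(Nc2ccccn2)c2ccc3cccnc3c2O)cc1` gives 460 nM.

Among these three numbers compound 3 stands second highest, but all three lie close together: the step of a 1.1-fold lower number from compound 1 to compound 3 (0.04 log units; within the scatter) and the step of a 1.2-fold higher number from compound 2 to compound 3 (0.09 log units; within the scatter) are both within the scatter, as is a 1.4-fold lower number from compound 1 to compound 2 (0.13 log units; within the scatter).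

Compound 4 `CCc1ccc(C(Nc2ccccn2)c2ccc3cccnc3c2O)cc1` differs from compound 3 by methyl in place of hydrogen on a saturated chain carbon bound to an aromatic carbon; cut one bond further out, the change reads methyl to ethyl, or 4-methylphenyl to 4-ethylphenyl. Going by the values given here, no measured step alters this group, so nothing bears on it directly. The two steps that come nearest, from compound 1 and from compound 2 to compound 3, each exchange the whole aryl group on that carbon and still stay within the scatter. A single added carbon is therefore expected to give no step beyond the scatter in this assay, in either direction.

Compound 4 is estimated at 460 nM, with a range from 200 nM to 1000 nM. That estimate means an expected step of no change at the digits printed from compound 3 to compound 4 (within the scatter).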

Compound 4, half-maximal inhibitory concentration: 170 nM
The estimate for compound 4 lay 2.7-fold (0.43 log units) above the measured number; the whole stated range lies above it.
By their numbers in this assay, from the lowest: compound 4; then compounds 2, 3 and 1 (each within the scatter of the next).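

In this assay, this position proves sensitive to a single added carbon: there is a 2.7-fold lower number from compound 3 to compound 4 (0.43 log units; beyond the scatter), although exchanging the whole aryl group among compound 1, compound 2 and compound 3 gave no step beyond the scatter. The 4-ethylphenyl group also sets compound 4 apart from the other two aryl groups that differ from it, with a 2.2-fold lower number from compound 2 to compound 4 (0.34 log units; beyond the scatter) and a 2.9-fold lower number from compound 1 to compound 4 (0.47 log units; beyond the scatter), making compound 4 the only one of the four whose steps to all the others lie beyond the scatter. Nothing on hand accounts for this difference between methyl and ethyl.

A single step cannot show whether a longer chain, as in 4-propylphenyl, or a branched isopropyl group would give a lower number, no change or a higher one. As far as these compounds go, it also remains open whether adding the same carbon would have a similar effect on an aryl group carrying a chlorine or a hydroxy group.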